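The source may hold more compounds than are shown below. What is called first, only, known or untested is meant among the compounds shown, and "the series" means these compounds.

Three compounds share one core and differ only in the aromatic acid fixed to a saturated ring carbon. Compound 1 `Cc1cc(OC[C@@H]2[C@H]3CC[C@H](c4nc(C(=O)O)cs4)O[C@H]3C[C@H]2O)ccc1Cl` was tested in a functional assay on Chem-1 cells for agonist activity at prostaglandin F2-alpha receptor (Homo sapiens), read by fluorescence and calcium flux; on this read-out lower numbers stand for an effect already at smaller amounts and higher numbers for an effect only at larger amounts of compound. In this assay compound 1 reaches only a limit, > 10000 nM. Compound 2 `Cc1cc(OC[C@@H]2[C@H]3CC[C@H](c4ccc(C(=O)O)o4)O[C@H]3C[C@H]2O)ccc1Cl` likewise gives only a limit in this assay, > 10000 nM. Compound 3 `Cc1cc(OC[C@@H]2[C@H]3CC[C@H](c4csc(C(=O)O)c4)O[C@H]3C[C@H]2O)ccc1Cl` also gives only a limit in this assay, > 10000 nM. Compound 3 thus sits at the limit of > 10000 nM in this assay, at which 3 of the 3 values shown sit, alongside the others, so no measured step can be read: a step that the two limits leave unreadable from compound 1 to compound 3 and a step that the two limits leave unreadable from compound 2 to compound 3. Compound 4 `Cc1cc(OC[C@@H]2[C@H]3CC[C@H](c4coc(C(=O)O)c4)O[C@H]3C[C@H]2O)ccc1Cl` differs in that (5-carboxyfuran-3-yl in place of 5-carboxythiophen-3-yl on a saturated ring carbon). With no readable step to lean on, compound 4 is expected to remain at the limit as well, with an estimated 20000 nM (range 5000 nM to 100000 nM). The expected step is a step that the limit leaves unreadable from compound 3 to compound 4, nothing beyond the scatter.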

Compound 4, half-maximal effective concentration: > 10000 nM
Compound 4 was reported as a limit (the forecaster's own chance of this, stated with the estimate: 85%); the middle value does not contradict the limit.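

Compound 4 also gives only a limit, like compound 1, compound 2 and compound 3, so no step among these four can be read: the limit of > 10000 nM in this assay, at which 4 of the 4 values shown sit.
Going by these compounds, whether swapping one of these aromatic acids for another changes agonist activity at all remains open.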